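The source may report more compounds than this note shows. Statements on the series, on what has been measured and on what is new or still open speak of the compounds shown alone.

For the measured compounds named here, in a functional assay on BaF3 cells (Mus musculus) for inhibition, read by CCK-8 assay, with a stated time of 72 h (a lower number here means a stronger inhibitor of growth, a higher number a weaker inhibitor of growth), only two related compounds have numbers so far. Compound 1 `CCN1CCN(Cc2ccc(NC(=O)Nc3ccc(Oc4cc(NC(C)=O)ncn4)cc3)cc2C(F)(F)F)CC1` gives 38 nM, while compound 2 `Cc1ccc(NC(=O)Nc2ccc(Oc3cc(NCc4ccccc4)ncn3)cc2)cc1C(F)(F)F` gives 3010 nM. Compound 2 therefore has the higher of the two numbers, and its gap to compound 1 lies beyond the scatter of repeat measurements, making it the weaker inhibitor of growth. These two compounds differ in more than one place, so their gap cannot be tied to any single group.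

Compound 3 `Cc1ccc(NC(=O)Nc2ccc(Oc3cc(N(C)CCN(C)C)ncn3)cc2)cc1C(F)(F)F` keeps the rest of compound 2 and changes one group, with (2-(dimethylamino)ethyl)(methyl)amino in place of benzylamino on an aromatic carbon. Going by the values given here, no measured pair isolates this swap, so the data give no direct guide to its effect, and the best starting point is the value of compound 2 at 3010 nM. No step beyond the scatter is expected, and the estimated shift is a 1.5-fold lower number from compound 2 to compound 3 (0.18 log units; within the scatter). That expectation is loose, since it could prove wrong in either direction. In this assay, compound 3 is estimated at 2000 nM, with an expected range from 400 nM to 8000 nM.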

Compound 3, concentration for 50% growth inhibition: 9410 nM
Compound 3: middle estimate off by 4.7-fold (0.67 log units), on the low side, outside the stated range (above it).
By their numbers in this assay, from the lowest: compound 1; then compound 2; then compound 3.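

For the compounds shown here, this is the first pair that isolates one change at this position of the shared core, the aromatic carbon next to the ring nitrogen. In this assay, putting (2-(dimethylamino)ethyl)(methyl)amino in place of benzylamino gives a 3.1-fold higher number from compound 2 to compound 3 (0.50 log units; beyond the scatter) and so a weaker inhibitor of growth; the step is modest but beyond the scatter, which shows that the group at this position can alter the read-out even when the rest of the molecule stays the same. The swap removes the six-membered aromatic ring and the hydrogen-bond donor and also adds a hydrogen-bond acceptor, and no measurement here shows which of these differences, if any, accounts for the step.

The compounds shown therefore leave open whether the ring or the donor matters more, a question that a smaller group such as methylamino or a ring-bearing group without a donor such as N-methylbenzylamino could help separate. Also open, from the compounds shown here alone, is how the acetylamino group of compound 1 would behave at this position on the otherwise unchanged frame of compound 2.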